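A Phenethyl Swap on a Permeable Quinoline-like Core

The source may hold more compounds than are shown below. What is called first, only, known or untested is meant among the compounds shown, and "the series" means these compounds.

Compound 1, `COc1ccccc1Oc1ccc2c(NCCCNCc3ccco3)ccnc2c1`, was tested in an ADME assay for permeability, using PAMPA, with a stated time of 30 min, at pH 7.4; a lower number here means that the compound crosses the layer more slowly, a higher number that the compound crosses the layer faster. In this assay compound 1 gives 317 10^-6 cm/s. Compound 3, `COc1cccc(CNCCCNc2ccnc3cc(Oc4ccc(Cl)cc4)ccc23)c1O`, gives 317 10^-6 cm/s in this assay, level with compound 1 at the digits shown and within the scatter of the method, so no order can be read between them; together they give the highest numbers of the three. Compound 2, `COc1ccc(F)cc1CNCCCNc1ccnc2cc(Cc3cc(C)cc(C)c3)ccc12`, gives 23 10^-6 cm/s in this assay, a markedly lower number than compound 1, beyond the scatter. Among the measured compounds shown here, no pair of these three compounds differs in only one place, so no single change can yet be tied to a measured step.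

Compound 4, `c1ccc(CCc2ccc3c(NCCCNCc4ccco4)ccnc3c2)cc1`, has not been measured. It differs from compound 1 in one place: phenethyl in place of 2-methoxyphenoxy on an aromatic carbon. The place is an aromatic carbon that is part of a fused system of two rings. The change is expected to give a step of a 1.1-fold lower number from compound 1 to compound 4 (0.05 log units; within the scatter), within the scatter. Compound 4 is therefore estimated at 280 10^-6 cm/s, in a range from 110 10^-6 cm/s to 450 10^-6 cm/s.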

Compound 4, apparent permeability: 23 10^-6 cm/s
Compound 4: the middle estimate sits 12-fold (1.09 log units) above what was measured; measured number outside the range, below it.
By their numbers in this assay, from the lowest: compounds 2 and 4 (each within the scatter of the next); then compounds 1 and 3 (each within the scatter of the next).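

This first single-place comparison shows that the group on this aromatic carbon of the fused system matters greatly in this assay: phenethyl in place of 2-methoxyphenoxy gives a large drop (a 14-fold lower number from compound 1 to compound 4 (1.14 log units; beyond the scatter)). The change is small on paper, since each group carries one six-membered aromatic ring of carbon only, with 9 heavy atoms leaving and 8 entering, while the 2 hydrogen-bond acceptors of 2-methoxyphenoxy are absent from phenethyl. Nothing measured here explains the drop, so this difference in counts remains a description and not a cause.

Still open, as far as these compounds go, is whether a benzyloxy group, which holds one oxygen and one aromatic ring, would sit closer to compound 1 or to compound 4. The compounds shown also leave open whether a simple methoxy group at this place, with no second aromatic ring, would keep the higher number.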